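Changing the aryl group at a clearance limit

The source may report more compounds than this note shows. Statements on the series, on what has been measured and on what is new or still open speak of the compounds shown alone.

Compound 1 (`COc1ccc(C(=O)Nc2[nH]nc(-c3ccccn3)c2C2CC2)cc1`): > 100 mL.min-1.g-1 (a limit of the assay)
Compound 2 (`COc1ccccc1C(=O)Nc1[nH]nc(-c2ccccn2)c1C1CC1`): > 100 mL.min-1.g-1 (a limit of the assay)

In an ADME assay on liver (Mesocricetus auratus) for metabolic stability, using microsomes (on this read-out lower numbers stand for slow clearance and higher numbers for fast clearance), compound 2 gives > 100 mL.min-1.g-1 as a limit of the assay, not a number. Compound 3 (`O=C(Nc1[nH]nc(-c2ccccn2)c1C1CC1)c1c(Cl)cccc1Cl`) has 2,6-dichlorophenyl in place of 2-methoxyphenyl on a carbonyl carbon. Among the compounds with values here, the one measured step (a step that the two limits leave unreadable from compound 1 to compound 2) offers no size to carry over, and both measured compounds share one limit (the limit of > 100 mL.min-1.g-1 in this assay, at which 2 of the 2 values shown sit). The expected step is therefore none beyond the scatter (a number no higher from compound 2 to compound 3 (the limit leaves the size open)), with no direction foreseen. The estimate for compound 3 is 100 mL.min-1.g-1 with an expected range from 35 mL.min-1.g-1 to 250 mL.min-1.g-1.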

Compound 3, intrinsic clearance in microsomes: > 100 mL.min-1.g-1
Compound 3: no number, only a limit; the forecaster's own chance of this, stated with the estimate: 55%; the middle value sits exactly at the limit.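

No step can be read among compound 1, compound 2 and compound 3, because all three give a limit of the assay rather than a number: the limit of > 100 mL.min-1.g-1 in this assay, at which 3 of the 3 values shown sit.

From the compounds shown here alone, the true clearance of each compound, and whether changing the group on the carbonyl carbon alters it, stays open.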